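This account rests on a few compounds, and the source may have more. Where it says the series, first, only, none or still open, it means among the compounds named here.

Compound 1 `COc1cc2c(cc1OC)C(CC(N)=O)CC2` gives 24.6% in a functional assay on the whole organism (strain Swiss albino) for inhibition, with Mus musculus as the target, in the writhing test, with stated times of 60 min and 15 min, at a dose of 100 mg/kg by the oral route; a lower number here means less inhibition, a higher number more inhibition at the dose given (going by the name of the read-out).
Compound 2 `CCCCCNC(=O)CC1CCc2cc(OC)c(OC)cc21` gives 71.7% in this assay.

Of the compounds shown here, two have been measured so far, and they share the same core; they differ only in what sits on the amide-type nitrogen. Compound 2 stands highest of the two numbers in this assay, and its nearest neighbour is compound 1, which lies well lower. Going by the values given here, the only step seen is a number 47.1 percentage points higher from compound 1 to compound 2 (beyond the scatter), where pentyl takes the place of hydrogen on that nitrogen.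

Compound 3 `COc1cc2c(cc1OC)C(CC(=O)N1CCNCC1)CC2` has not yet been measured. It differs from compound 2 by piperazin-1-yl in place of pentylamino on a carbonyl carbon. Among the compounds with values here, no measured step covers this exchange of one group on the carbonyl carbon for another, so the single step from compound 1 to compound 2 can guide only loosely: it shows that the group on the amide nitrogen matters a great deal, but not which way a ring-bearing group will move the number. A downward step is therefore expected, a number 21.7 percentage points lower from compound 2 to compound 3 (beyond the scatter), with wide uncertainty. Compound 3 is estimated to give 50% in this assay, somewhere between 25% and 75%.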

Compound 3, a percentage reported as inhibition, in the whole organism at one dose (the size of the read-out at that dose, not a potency): 68.8%
Estimate against measurement, compound 3: 18.8 percentage points below; low and high end bracket the measured number.
By their numbers in this assay, from the lowest: compound 1; then compounds 3 and 2 (each within the scatter of the next).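

Replacing pentylamino with piperazin-1-yl on the carbonyl carbon gives a number 2.9 percentage points lower from compound 2 to compound 3 (within the scatter) in this assay, so here an open chain and a six-membered non-aromatic ring with 2 hetero atoms cannot be told apart by this read-out, even though the two groups differ in shape and in their atoms. Set against the plain amide, the same ring gives a number 44.2 percentage points higher from compound 1 to compound 3 (beyond the scatter), which shows that the large gain seen with pentyl on the amide nitrogen does not depend on a chain: among the compounds shown, both larger groups that replace amino give it, and neither goes against this. No measurement here bears on why the two groups read alike.

Going by these compounds alone, with only two such groups, it remains open how much of the gain depends on the size of the group and how much on its kind: ethylamino or a longer chain such as octylamino would test the first, and morpholin-4-yl or 4-methylpiperazin-1-yl the second. Because every number comes from a single dose, these figures also leave open whether compound 2 and compound 3 would still match at lower doses.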